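Swapping the aryl group on the thiourea of compound 3

The source may hold more compounds than are shown below. What is called first, only, known or untested is meant among the compounds shown, and "the series" means these compounds.

Among the compounds with values here, in a functional assay on HepG2 cells (Homo sapiens) for antiproliferative activity, read by MTT assay (a higher number here means a weaker inhibitor, a lower number a stronger inhibitor), compound 3 `CNC(=O)c1ccc(Oc2cccc(NC(=S)Nc3cccc(C(F)(F)F)c3)c2)nc1` gives 23300 nM, the lowest of the two numbers so far; compound 1 `CNC(=O)c1ccc(Oc2cccc(NC(=S)Nc3ccc(Cl)cc3)c2)nc1` gives 29400 nM, and the step of a 1.3-fold lower number from compound 1 to compound 3 (0.10 log units; within the scatter) lies within the scatter. Compound 2 `CNC(=O)c1ccc(Oc2cccc(NC(=S)Nc3ccc(OC(F)(F)F)cc3)c2)nc1` reaches only the limit > 100000 nM in this assay, noted as the limit of > 100000 nM in this assay, at which 1 of the 3 values shown sits. Compound 4 `CNC(=O)c1ccc(Oc2cccc(NC(=S)Nc3ccc(OC)cc3)c2)nc1` carries the change (4-methoxyphenyl in place of 3-(trifluoromethyl)phenyl on an amide-type nitrogen). The aryl swap a 1.3-fold lower number from compound 1 to compound 3 (0.10 log units; within the scatter) changed little, whereas the change of substituent an at least 3.4-fold higher number from compound 1 to compound 2 (0.53 log units; beyond the scatter) weakened the compound at least modestly. A small weakening or no step beyond the scatter is therefore expected, a 1.7-fold higher number from compound 3 to compound 4 (0.23 log units; within the scatter). Compound 4 is estimated at 40000 nM, between 15000 nM and 100000 nM.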

Compound 4, half-maximal inhibitory concentration: 85300 nM
Estimate against measurement, compound 4: 2.1-fold (0.33 log units) below; measured number inside the range.
By their numbers in this assay, from the lowest: compounds 3 and 1 (each within the scatter of the next); then compound 4. At a limit, above all of these: compound 2.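

Here the aryl group on the amide-type nitrogen makes a clear difference, which the step between compound 1 and compound 3 did not show. 4-Methoxyphenyl gives a weaker compound than either other aryl group with a measured number (a 3.7-fold higher number from compound 3 to compound 4 (0.56 log units; beyond the scatter) and a 2.9-fold higher number from compound 1 to compound 4 (0.46 log units; beyond the scatter)). Compound 2 stands at a limit: the limit of > 100000 nM in this assay, at which 1 of the 4 values shown sits.

Read against that limit, the remaining step is only a floor (an at least 1.1-fold lower number from compound 2 to compound 4 (0.06 log units; that floor lies within the scatter)) and sets no order between these two compounds.

From the compounds shown here alone, whether the loss follows the methoxy group itself or its place on the ring remains open. So does how a 3-methoxyphenyl group, or a phenyl ring carrying an amine, would compare with compound 3.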